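Growing the Ester Chains in a Calcium Channel Series

The source may hold more compounds than are shown below. What is called first, only, known or untested is meant among the compounds shown, and "the series" means these compounds.

Of the compounds shown here, three built on one shared core have been tested in an assay on isolated protein for antagonist activity at Voltage-dependent L-type calcium channel subunit alpha-1C (Cavia porcellus), with a stated time of 15 min; a higher number here means a weaker inhibitor, a lower number a stronger inhibitor. Compound 1 `CCCOC(=O)C1=C(C)NC(C)=C(C(=O)OC)C1c1csc(-c2ccc(Cl)cc2)n1` gives 5920 nM. Compound 2 `COC(=O)C1=C(C)NC(C)=C(C(=O)OCC(C)C)C1c1csc(-c2ccc(Cl)cc2)n1` gives 46900 nM, and compound 3 `COC(=O)C1=C(C)NC(C)=C(C(=O)OC2CCCCC2)C1c1csc(-c2ccc(Cl)cc2)n1` gives 71900 nM. Compound 1 is the strongest inhibitor of the three: the step of a 7.9-fold higher number from compound 1 to compound 2 (0.90 log units; beyond the scatter) comes from methyl in place of hydrogen on a saturated chain carbon bound to two saturated chain carbons, and the step of a 12-fold higher number from compound 1 to compound 3 (1.08 log units; beyond the scatter) comes from cyclohexyl in place of propyl on an oxygen next to a carbonyl group. Between compound 2 and compound 3 the step of a 1.5-fold higher number from compound 2 to compound 3 (0.19 log units; within the scatter) cannot be told apart from repeat measurement.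

Compound 4 `CCOC(=O)C1=C(C)NC(C)=C(C(=O)OC2CCCCC2)C1c1csc(-c2ccc(Cl)cc2)n1` has not been measured. It differs from compound 3 by methyl in place of hydrogen on a saturated chain carbon bound to an oxygen next to a carbonyl group. Going by the values given here, this is the same kind of change as the one from compound 1 to compound 2, which gave a 7.9-fold higher number from compound 1 to compound 2 (0.90 log units; beyond the scatter), but the surroundings are not identical: there the methyl entered on a saturated chain carbon bound to two saturated chain carbons, whereas here it enters on a saturated chain carbon bound to an oxygen next to a carbonyl group. The two starting cores also differ, by cyclohexyl in place of propyl on an oxygen next to a carbonyl group.

Among the compounds with values here, only one earlier example of this kind of change exists, and it sits in a different place, so the expectation rests loosely on it. For compound 4 the step of a 1.5-fold higher number from compound 3 to compound 4 (0.18 log units; within the scatter) is expected, smaller than the earlier one, because compound 3 already gives 71900 nM and the added methyl here is a smaller change of the chain. Compound 4 is estimated at 110000 nM, expected to fall between 45000 nM and 270000 nM.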

Compound 4, half-maximal inhibitory concentration: 100000 nM
Compound 4: the middle estimate sits 1.1-fold (0.04 log units) above what was measured; measured number inside the range.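

Adding one methyl does not carry a single size of effect from one core to another in this series in this assay: the same change on two cores in this assay, a 7.9-fold higher number (0.90 log units; beyond the scatter) from compound 1 to compound 2 and a 1.4-fold higher number (0.14 log units; within the scatter) from compound 3 to compound 4, 5.7-fold (0.76 log units) apart, beyond the scatter of two such steps On the core of the newer pair, the methyl that turns methoxycarbonyl into ethoxycarbonyl gives a 1.4-fold higher number from compound 3 to compound 4 (0.14 log units; within the scatter), so this pair shows no readable effect of the change. In one pair the methyl enters on a saturated chain carbon bound to two saturated chain carbons, in the other on a saturated chain carbon bound to an oxygen next to a carbonyl group, and the cores differ as well. Two pairs cannot separate the effect of place from that of core.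

The compounds shown leave open whether the turn from methoxycarbonyl to ethoxycarbonyl would give a clearer step on the core of compound 1, where the other ester is a propyl chain rather than a cyclohexyl ring. They also leave open how a longer chain, or an ester chain ending in an amine or a carboxylic acid, would behave on the shared core.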